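Half-life notes: chain substituent step from compound 3 to compound 4

The compounds below may be only part of what the source reports. "The series", "measured", "known", "first", "only" and "open" are said of these compounds alone.

Measured so far in an in vitro ADME assay on microsomes from liver (Homo sapiens) for metabolic stability, tested at 5 uM; on this read-out lower numbers stand for a shorter-lived compound and higher numbers for a longer-lived compound:
- Compound 1, `CC(C)CCn1nc(-c2cccs2)c(O)c(C2=NS(=O)(=O)c3cc(N(C)S(C)(=O)=O)ccc3N2)c1=O`, gives 0.467 h.
- Compound 2, `CCC(C)CCn1nc(-c2cccs2)c(O)c(C2=NS(=O)(=O)c3cc(NS(C)(=O)=O)ccc3N2)c1=O`, gives > 1 h, which is a limit of the assay.
- Compound 3, `COC(C)(C)CCn1nc(-c2cccs2)c(O)c(C2=NS(=O)(=O)c3cc(NS(C)(=O)=O)ccc3N2)c1=O`, gives > 1 h, again a limit of the assay.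

Compound 3 thus stands at the upper boundary of what this assay reports, alongside compound 2, while compound 1 sits lower. Among the measured compounds shown here, the one step within one difference, a step that the two limits leave unreadable from compound 2 to compound 3, cannot be sized, since (the limit of > 1 h in this assay, at which 2 of the 3 values shown sit).

Compound 4, `CS(=O)(=O)Nc1ccc2c(c1)S(=O)(=O)N=C(c1c(O)c(-c3cccs3)nn(CCC3CCCC3)c1=O)N2`, differs from compound 3 by cyclopentyl in place of 1-methoxy-1-methylethyl on a saturated chain carbon, two bonds along the chain from an aromatic nitrogen. For the measured compounds named here, no measured step bears on this change, so no direction beyond the scatter is expected, and compound 3's limit leaves its true value open. Compound 4 is estimated at 1 h, range 0.4 h to 2.5 h, with an expected step of a number no higher from compound 3 to compound 4 (the limit leaves the size open).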

Compound 4, half-life: > 1 h
Compound 4: a limit, no number; the forecaster's own chance of this, stated with the estimate: 50%; the middle value lies on the limit itself.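

No new step can be read among compound 2, compound 3 and compound 4, because all three sit at one limit: the limit of > 1 h in this assay, at which 3 of the 4 values shown sit.

Going by these compounds, whether sec-butyl, 1-methoxy-1-methylethyl and cyclopentyl differ at all in half-life stays open.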